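The source may hold more compounds than are shown below. What is called first, only, known or untested is meant among the compounds shown, and "the series" means these compounds.

In a functional assay on HeLa cells (Homo sapiens) for inhibition, read by MTT assay, with a stated time of 72 h (a lower number here means a stronger inhibitor, a higher number a weaker inhibitor), compound 2 (`COc1cc(OC)c(OC)cc1/C=C/C(=O)c1ccccc1`) gives > 150000 nM, and this is a limit of the assay, not a number. Its true position is therefore unknown, and it sits at the weak end of what has been measured. Compound 1 (`COc1cc(OC)c(OC)cc1/C=C/C(=O)c1ccc(Cl)cc1`) shares the same core, carries a chloro group instead of that hydrogen, and gives a real reading of 36500 nM. Putting hydrogen in place of chloro on an aromatic carbon gave an at least 4.1-fold higher number from compound 1 to compound 2 (0.61 log units; beyond the scatter).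

Compound 3 (`COc1cc(OC)c(OC)cc1/C=C/C(=O)c1ccc(-c2c[nH]cn2)cc1`) changes that same aromatic carbon, para to a large group: 1H-imidazol-4-yl in place of hydrogen on an aromatic carbon. Within the data shown here, this is the only measured step that bears on the change, and it comes from a much smaller group. It suggests that filling this spot can bring a measurable effect, so a move towards a lower number is expected, though an imidazole is not a chloro group and the size remains uncertain. In this assay, the expected change is an at least 6.0-fold lower number from compound 2 to compound 3 (0.77 log units; beyond the scatter), at least as large as the chloro step. For compound 3 the estimated value is 25000 nM, with an expected range from 6000 nM to 100000 nM.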

Compound 3, half-maximal inhibitory concentration: > 150000 nM
Compound 3 was reported as a limit; the forecaster's own chance of this, stated with the estimate: 20%; middle value at least 6.0-fold (0.77 log units) from the limit.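

Putting 1H-imidazol-4-yl in place of chloro on this aromatic carbon gave an at least 4.1-fold higher number from compound 1 to compound 3 (0.61 log units; beyond the scatter) in this assay and so lost the measurable reading that compound 1 has. Among the three compounds, only the chloro group gives a real number at this position, so filling the spot is not enough on its own: a larger group with a five-membered aromatic ring does not carry the gain over. The step between the unsubstituted compound 2 and compound 3 cannot be read, since both values are only limits and neither compound can be placed ahead of the other: the limit of > 150000 nM in this assay, at which 2 of the 3 values shown sit.

On these data alone, how far compound 2 and compound 3 truly lie beyond that limit stays open, as does whether the imidazole changes activity at all. As far as these compounds go, it is also open whether the reading of compound 1 is special to chloro or would be shared by a fluoro, bromo or methyl group at the same carbon, and whether a phenyl ring, an amine or a carboxylic acid there would give a real number.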